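The source may hold more compounds than are shown below. What is called first, only, known or untested is meant among the compounds shown, and "the series" means these compounds.

Compound 1 `COc1nc(N)nc2c1c(-c1ccccc1)cn2[C@@H]1O[C@H](CO)[C@@H](O)[C@H]1O` and compound 2 `COc1nc(N)nc2c1c(-c1cccs1)cn2[C@@H]1O[C@H](CO)[C@@H](O)[C@H]1O` share one core, while compound 3 `CNc1ncnc2c1c(-c1ccccc1)cn2[C@@H]1O[C@H](CO)[C@@H](O)[C@H]1O` carries another; the difference between the two cores is not broken down here. In a functional assay on CCRF-CEM cells (Homo sapiens), read by MTT assay, with a stated time of 72 h (a higher number here means a weaker inhibitor, a lower number a stronger inhibitor), compound 1 gives > 20000 nM, a limit of the assay. In this assay compound 2 gives > 20000 nM, likewise a limit. The change is thiophen-2-yl in place of phenyl on an aromatic carbon, and the two limits leave the step that the two limits leave unreadable from compound 1 to compound 2 unreadable. In this assay compound 3 gives > 20000 nM, also a limit. Compound 4 `CNc1ncnc2c1c(-c1cccs1)cn2[C@@H]1O[C@H](CO)[C@@H](O)[C@H]1O` is not yet measured and differs from compound 3 by thiophen-2-yl in place of phenyl on an aromatic carbon, the same kind of change, the place here described only as bearing a group of 9 heavy atoms rather than the named 3,4-dihydroxy-5-(hydroxymethyl)oxolan-2-yl group. Because (the limit of > 20000 nM in this assay, at which 3 of the 3 values shown sit), compound 4 is expected to remain at a limit, with an expected step that the limit leaves unreadable from compound 3 to compound 4. Compound 4 is estimated at 40000 nM.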

Compound 4, half-maximal inhibitory concentration: > 20000 nM
Compound 4: a limit, no number (the forecaster's own chance of this, stated with the estimate: 85%); the middle value does not contradict the limit.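

Compound 3 and compound 4 both sit at a limit, so no step can be read between them. The compounds shown leave open how strongly any of them acts in this assay, and whether thiophen-2-yl or phenyl gives the stronger inhibitor.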